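Chain extension on the acyl group of a pyrazoline

The compounds below may be only part of what the source reports. "The series", "measured", "known", "first", "only" and "open" are said of these compounds alone.

The measured compounds and their values:
compound 1 `CCCC(=O)N1CCC(c2cc(Cl)ccc2N)=N1` 0.29%
compound 2 `COc1ccc(N)c(C2=NN(C(C)=O)CC2)c1` 20.4%
compound 3 `CCC(=O)N1CCC(c2cc(OC)ccc2N)=N1` 20.4%

In an assay on isolated protein for inhibition of Nitric oxide synthase, inducible (Homo sapiens), with a stated time of 30 min, tested at 1 mM (on this read-out higher numbers stand for more inhibition at the one concentration tested (going by the name of the read-out) and lower numbers for less inhibition), compound 3 gives 20.4%. It stands level with compound 2 at the digits shown, and together these two are the highest of the three numbers. Compound 1 lies further away, with a value lower by more than the scatter; since compound 1 differs from compound 3 in more than one place, only the two values themselves can be compared.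

The next compound is compound 4 `CCCC(=O)N1CCC(c2cc(OC)ccc2N)=N1`, which differs from compound 3 as follows: methyl in place of hydrogen on a saturated chain carbon, two bonds along the chain from a carbonyl carbon.

Among the measured compounds shown here, one measured step bears directly on this change. The same kind of lengthening of the acyl chain gave no change at the digits printed from compound 2 to compound 3 (within the scatter), that is, no change beyond the scatter. That step is the nearest analogue of the present one, as it adds the same unit to the same chain one bond closer to the carbonyl. On this basis the step from compound 3 to compound 4 in this assay is expected to be small, a number 0.4 percentage points lower from compound 3 to compound 4 (within the scatter), in no clear direction.

Compound 4 is therefore estimated at 20% in this assay, with a range from 5% to 35%.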

Compound 4, a percentage reported as inhibition, at one concentration (the size of the read-out at that concentration, not a potency): 13.1%
The estimate for compound 4 lay 6.9 percentage points above the measured number; the range from low to high includes it.
By their numbers in this assay, from the lowest: compound 1; then compounds 4, 2 and 3 (each within the scatter of the next).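

In this assay, methyl in place of hydrogen two bonds along the chain from the carbonyl carbon gives (a number 7.3 percentage points lower from compound 3 to compound 4 (within the scatter)), and the full extension, ethyl in place of hydrogen on the saturated chain carbon bound to the carbonyl carbon, gives (a number 7.3 percentage points lower from compound 2 to compound 4 (within the scatter)). Both steps stay within the scatter, so the acyl chain shows no clear effect on the number across these three chain lengths, even though the read-out now moves more than it did on the first lengthening. Among the compounds shown here, the propylcarbonyl chain also gives the first comparison that differs in only one place on the aromatic side, and methoxy in place of chloro on an aromatic carbon gives (a number 12.8 percentage points higher from compound 1 to compound 4 (beyond the scatter)), a modest step that stands beyond the scatter.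

Going by these compounds, it remains open whether a longer chain, a branched acyl group or an acyl group carrying an amine would stay level with these compounds, and whether the gain from methoxy over chloro holds with the shorter acyl chains. No measurement on hand accounts for either the flat chain series or the aromatic step.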